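A Sulfonamide Replaces the Amide on the Shared Core

The source may hold more compounds than are shown below. What is called first, only, known or untested is meant among the compounds shown, and "the series" means these compounds.

Compound 1 `CN(C(=O)C(C)(C)C)c1ccc2[nH]c(-c3n[nH]c4ccccc34)cc2n1`: 18000 nM
Compound 2 `CN(C(=O)c1ccc(Br)cc1)c1ccc2[nH]c(-c3n[nH]c4ccccc34)cc2n1`: 6110 nM
Compound 3 `COc1cccc(C(=O)N(C)c2ccc3[nH]c(-c4n[nH]c5ccccc45)cc3n2)c1`: 14200 nM

Of the compounds shown here, three sharing one core have been measured in a functional assay on HCT-116 cells (Homo sapiens) for antiproliferative activity, read by MTT assay, with a stated time of 72 h (a lower number here means a stronger inhibitor, a higher number a weaker inhibitor), and differ only in the group on the carbonyl carbon. In this assay compound 3 gives 14200 nM, which places it second highest of the three numbers: its nearest neighbour is compound 1, and the difference between them, a 1.3-fold lower number from compound 1 to compound 3 (0.10 log units; within the scatter), stays within the scatter, while the gap to compound 2, a 2.3-fold higher number from compound 2 to compound 3 (0.37 log units; beyond the scatter), lies beyond it.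

Compound 4 `CN(c1ccc2[nH]c(-c3n[nH]c4ccccc34)cc2n1)S(=O)(=O)c1ccc(Cl)cc1` has not been measured. It differs from compound 3 by (4-chlorophenyl)sulfonyl in place of (3-methoxyphenyl)carbonyl on a nitrogen on an aromatic ring. Within the data shown here, no measured step covers the exchange of a carbonyl for a sulfonyl, so only the aryl part can be compared. The step of a 2.9-fold lower number from compound 1 to compound 2 (0.47 log units; beyond the scatter) shows that a 4-bromophenyl group on the carbonyl gave a modest drop in the number, and a 2.3-fold higher number from compound 2 to compound 3 (0.37 log units; beyond the scatter) shows the 3-methoxyphenyl group lying modestly higher than that. On this basis a modest lowering is expected for compound 4, of about a 1.8-fold lower number from compound 3 to compound 4 (0.25 log units; within the scatter), with wide uncertainty. The estimate for compound 4 in this assay is 8000 nM, within a range from 3000 nM to 25000 nM.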

Compound 4, half-maximal inhibitory concentration: 5980 nM
Compound 4: the middle estimate sits 1.3-fold (0.13 log units) above what was measured; the range from low to high includes it.
By their numbers in this assay, from the lowest: compounds 4 and 2 (each within the scatter of the next); then compounds 3 and 1 (each within the scatter of the next).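

On the nitrogen on an aromatic ring, the shared core keeps its activity in this assay when a (4-chlorophenyl)sulfonyl group takes the place of a carbonyl-linked group: compound 4 stays level with the 4-bromophenyl amide (a 1.0-fold lower number from compound 2 to compound 4 (0.01 log units; within the scatter)). The same exchange gives a modest lowering against the 3-methoxyphenyl amide (a 2.4-fold lower number from compound 3 to compound 4 (0.38 log units; beyond the scatter)) and the tert-butyl amide (a 3.0-fold lower number from compound 1 to compound 4 (0.48 log units; beyond the scatter)), so the two compounds with a halogen-bearing phenyl group read alike across different linkers, while compounds 1 and 3 read higher. No measurement available here explains these differences. The linker and the aryl group change together in every step to compound 4, so their separate contributions remain unresolved. Also open, on these data alone, is how a methanesulfonyl group, or a sulfonyl carrying a 3-methoxyphenyl group, would read at this nitrogen.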